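A few compounds are considered here, and "the series" means these few. Any claim that something is new, unique, unknown or untested is made for them only; others in the source may bear on it.

In a functional assay on HL-60 cells (Homo sapiens) for inhibition, read by CCK-8 assay, with a stated time of 48 h, tested at 20 uM (a lower number here means less inhibition of growth, a higher number more inhibition of growth at the concentration tested), compound 1 `COc1ccc(S(=O)(=O)Oc2ccccc2/C=C(\C#N)C(=O)Nc2nnc(Cc3cccc4ccccc34)s2)cc1` gives 98% and compound 2 `COc1ccc(S(=O)(=O)Oc2ccccc2/C=C(\C#N)C(=O)Nc2nnc(Cc3ccccc3)s2)cc1` gives 100%. The step between them, a number 2 percentage points higher from compound 1 to compound 2 (within the scatter), places phenyl where naphthalen-1-yl stood and stays within the scatter. Compound 3 `Cc1ccc(S(=O)(=O)Oc2ccccc2/C=C(\C#N)C(=O)Nc2nnc(Cc3cccc(F)c3)s2)cc1` is the lowest of the three at 11%, beyond the scatter from both of the others.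

Compound 4 `COc1ccc(S(=O)(=O)Oc2ccccc2/C=C(\C#N)C(=O)Nc2nnc(Cc3cccc(F)c3)s2)cc1` follows from compound 3 by methoxy in place of methyl on an aromatic carbon, para to a large group: methoxy in place of methyl on an aromatic carbon. This exchange of 4-methylphenyl to 4-methoxyphenyl has not been measured on its own in this series. Going by the values given here, the single measured step lies elsewhere in the structure and does not give its size. Compound 4 shares the methoxy group with compounds 1 and 2, but compound 3 also differs from those two at a second place, so the data do not divide their gap between the two places.

The expected direction is upward because compound 2 with its methoxy group reads 100%. The estimated change is large but uncertain, a number 54 percentage points higher from compound 3 to compound 4 (beyond the scatter). For compound 4 the estimate is 65%, with an expected range from 20% to 100%.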

Compound 4, percent growth inhibition at one concentration: 100%
Compound 4: middle estimate off by 35 percentage points, on the low side; the range from low to high includes it.
By their numbers in this assay, from the lowest: compound 3; then compounds 1, 2 and 4 (each within the scatter of the next).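

Going by these compounds alone, with the 3-fluorophenyl end held constant, the exchange of 4-methylphenyl for 4-methoxyphenyl alone gives, in this assay, a number 89 percentage points higher from compound 3 to compound 4 (beyond the scatter), so this position can carry a gap of that size on its own, which the earlier compounds could not show because they differed from compound 3 at two places. With the methoxy group in place, the other end of the molecule shows no separation in these readings: fluoro in place of hydrogen gives no change at the digits printed from compound 2 to compound 4 (within the scatter), and 3-fluorophenyl in place of naphthalen-1-yl gives a number 2 percentage points higher from compound 1 to compound 4 (within the scatter). No supporting data bear on the origin of the methyl-to-methoxy difference.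

Whether methyl at this position gives a similarly low reading alongside phenyl or naphthalen-1-yl remains open, as the shown methyl compound carries only 3-fluorophenyl. Also open, going by these compounds, is how a hydroxy, ethoxy or dimethylamino group would read at this position, and how compound 1, compound 2 and compound 4 would rank at lower concentrations, since a single concentration does not separate them.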